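The source may report more compounds than this note shows. Statements on the series, on what has been measured and on what is new or still open speak of the compounds shown alone.

Compound 1 `C=C(c1ccc(OC)cc1NC(=O)CN)c1ccc(OC)c2c1OC(C)(C)C=C2` gives 220 nM in a functional assay on MCF7 cells (Homo sapiens) for antiproliferative activity, read by MTT assay, with a stated time of 48 h; a higher number here means a weaker inhibitor, a lower number a stronger inhibitor. Compound 3 `C=C(c1ccc(OC)cc1NC(=O)CNC)c1ccc(OC)c2c1OC(C)(C)C=C2` differs from it by methyl in place of hydrogen on an amine nitrogen and gives 400 nM in this assay; the step of a 1.8-fold higher number from compound 1 to compound 3 (0.26 log units; within the scatter) is recorded with it. Compound 2 `C=C(c1ccc2c(c1)C=CC(C)(C)O2)c1ccc(OC)cc1NC(=O)CN` sits on a second core; the difference between the two cores is not broken down here. In this assay compound 2 gives 420 nM, a value lying with those of compound 1 and compound 3 inside the usual scatter, so no order among the three is drawn.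

Compound 4 `C=C(c1ccc2c(c1)C=CC(C)(C)O2)c1ccc(OC)cc1NC(=O)CNC` is compound 2 carrying (methyl in place of hydrogen on an amine nitrogen), and the surroundings of the place are the same as for the earlier pair, so it is the same change. For compound 4 the step of a 1.8-fold higher number from compound 2 to compound 4 (0.25 log units; within the scatter) is expected, resting on the earlier step of a 1.8-fold higher number from compound 1 to compound 3 (0.26 log units; within the scatter) from the other core. Compound 4 is therefore estimated at 750 nM, expected within 350 nM to 1600 nM.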

Compound 4, half-maximal inhibitory concentration: 720 nM
Beside the measured number, compound 4's estimate is 1.0-fold (0.02 log units) above it; measured number inside the range.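

In this assay, the new step is a 1.7-fold higher number from compound 2 to compound 4 (0.23 log units; within the scatter), and methyl in place of hydrogen on an amine nitrogen reads alike on the two cores: the same change on two cores in this assay, a 1.8-fold higher number (0.26 log units; within the scatter) from compound 1 to compound 3 and a 1.7-fold higher number (0.23 log units; within the scatter) from compound 2 to compound 4, 1.1-fold (0.03 log units) apart, within the scatter of two such steps. Within this one pair of cores, the change carries over with no sign of dependence on the core. Since each step lies within the scatter, this agreement does not establish that the methyl itself shifts the number, and two cores say nothing about a third.

Still open, as far as these compounds go, is whether a larger group on that nitrogen, such as ethyl or acetyl, or a second methyl giving a tertiary amine, would move the number beyond the scatter. From the compounds shown here alone, a longer chain in place of aminomethyl also remains open.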